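A Bromo Swap Among Compounds Held at Limits

The compounds below may be only part of what the source reports. "The series", "measured", "known", "first", "only" and "open" are said of these compounds alone.

In a functional assay (Homo sapiens) for cytotoxicity (on this read-out higher numbers stand for weaker inhibition and lower numbers for stronger inhibition), compound 1 `Cc1c([Se]c2ccccc2)n(COCCO)c(=O)[nH]c1=O` gives > 200000 nM as a limit and not a number. Compound 2 `O=c1[nH]c(=O)n(COCCO)c([Se]c2ccccc2)c1F` gives > 100000 nM which is also a limit. Compound 3 `O=c1[nH]c(=O)n(COCCO)c([Se]c2ccccc2)c1Cl` gives > 100000 nM as a limit too, so it has no exact position. Compound 4 `O=c1[nH]c(=O)n(COCCO)c([Se]c2ccccc2)c1Br` differs from compound 3 by bromo in place of chloro on an aromatic carbon with bromo in place of chloro on an aromatic carbon. The closest evidence is a step that the two limits leave unreadable from compound 2 to compound 3 and the others are a step that the two limits leave unreadable from compound 1 to compound 2 and a step that the two limits leave unreadable from compound 1 to compound 3 so none gives a size. With compound 3 at > 100000 nM as a limit, no step beyond the scatter is expected in either direction. The expected change is a step that the limit leaves unreadable from compound 3 to compound 4 in this estimate. For compound 4 the estimated value is 120000 nM with an expected range of 50000 nM to 300000 nM here.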

Compound 4, half-maximal inhibitory concentration: > 100000 nM
Compound 4 was reported as a limit; the forecaster's own chance of this, stated with the estimate: 85%; the middle value is on the limit's open side.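

Compound 4 is reported only as a limit, as are compound 1, compound 2 and compound 3, so the steps to compound 4 cannot be read. Going by these compounds, the true values of all four compounds, and any differences among them, remain open.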